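Difluorophenyl anilide on the core of compound 1

The compounds below may be only part of what the source reports. "The series", "measured", "known", "first", "only" and "open" are said of these compounds alone.

Compound 1 `Cc1ccc(NC(=O)CN2CCN(c3nnc(Cc4ccncc4)c4ccccc34)CC2)c(C)c1` gives the lowest of the three measured numbers in a functional assay on HT-29 cells (Homo sapiens) for cytotoxicity, read by MTT assay, with a stated time of 72 h (on this read-out higher numbers stand for weaker inhibition and lower numbers for stronger inhibition), at 1930 nM. Compound 2 `Cc1ccc(F)cc1NC(=O)CN1CCN(c2nnc(Cc3ccccc3)c3ccccc23)CC1` gives 171000 nM and compound 3 `Cc1ccccc1NC(=O)CN1CCN(c2nnc(Cc3ccccc3)c3ccccc23)CC1` gives 113000 nM; both differ from compound 1 in more than one place, so neither gap is a single-change step. For the measured compounds named here, the only measured step on the anilide ring, a 1.5-fold lower number from compound 2 to compound 3 (0.18 log units; within the scatter), is small. Compound 4 `O=C(CN1CCN(c2nnc(Cc3ccncc3)c3ccccc23)CC1)Nc1ccc(F)c(F)c1` carries 3,4-difluorophenyl in place of 2,4-dimethylphenyl on an amide-type nitrogen. Going by the values given here, that change is larger than one fluoro for one hydrogen, and no measured pair covers it; the single anilide step sits within the scatter. Compound 4 is therefore expected to shift modestly toward a higher number, a 3.1-fold higher number from compound 1 to compound 4 (0.49 log units; beyond the scatter), with wide uncertainty. The estimate for compound 4 is 6000 nM, within a range of 1500 nM to 30000 nM.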

Compound 4, half-maximal inhibitory concentration: 2320 nM
Compound 4: middle estimate off by 2.6-fold (0.41 log units), on the high side; measured number inside the range.
By their numbers in this assay, from the lowest: compounds 1 and 4 (each within the scatter of the next); then compounds 3 and 2 (each within the scatter of the next).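

On the core of compound 1, 3,4-difluorophenyl in place of 2,4-dimethylphenyl on the amide-type nitrogen gives, in this assay, a 1.2-fold higher number from compound 1 to compound 4 (0.08 log units; within the scatter). For the compounds shown here, both methyl groups can thus leave and two fluorines enter without a change beyond the scatter, a wider exchange than the single fluoro-to-hydrogen step a 1.5-fold lower number from compound 2 to compound 3 (0.18 log units; within the scatter). Nothing measured here explains this result. Still open, from the compounds shown here alone, is how this position responds to a group of another kind, such as a carboxylic acid or an amine on the anilide ring. Also open, going by these compounds, is whether a saturated cyclohexyl group could replace the aromatic ring on that nitrogen.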